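The compounds below may be only part of what the source reports. "The series", "measured", "known", "first", "only" and "open" are said of these compounds alone.

Measured so far:
- compound 1, `Nc1cc(N)c2nc(-c3ccccc3)c(Oc3ccc(Cl)c(Cl)c3)nc2c1`: 41700 nM
- compound 2, `Nc1cc(N)c2nc(-c3ccccc3)c(NCc3ccc(Cl)c(Cl)c3)nc2c1`: < 100000 nM
- compound 3, `CCOC(=O)[C@H](CCC(=O)O)NC(=O)c1ccc(Sc2nc3cc(N)cc(N)c3nc2-c2ccccc2)cc1`: < 100000 nM

Of the compounds shown here, three built on the same core have been tested in a functional assay on EKVX cells (Homo sapiens) for inhibition, read by sulforhodamine B assay, with a stated time of 48 h; a lower number here means that less compound is tolerated, a higher number that more compound is tolerated. Going by the values given here, compound 1 gives 41700 nM, and this is the only true number among the three. For compound 2 the result < 100000 nM is a limit of the assay, not a number. For compound 3 likewise the result < 100000 nM is a limit. So compound 1 stands alone as the one compound with a measured figure, while the other two sit at the limit of < 100000 nM in this assay, at which 2 of the 3 values shown sit.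

Compound 4, `Nc1cc(N)c2nc(-c3ccccc3)c(Sc3ccc(F)cc3)nc2c1`, has not yet been tested. It keeps the core of compound 1 and changes one substituent: (4-fluorophenyl)sulfanyl in place of 3,4-dichlorophenoxy on an aromatic carbon. The new group takes the place on an aromatic carbon of a six-membered aromatic ring with 2 nitrogen, part of a fused or bridged system of two rings, ortho to a phenyl group.

Among the compounds with values here, no measured pair differs in just this place, so the size of the step in this assay rests on compound 1 alone. Because compound 1 gives 41700 nM, the expectation for compound 4 is a step of a 1.0-fold lower number from compound 1 to compound 4 (0.02 log units; within the scatter), within the usual scatter. Compound 4 is therefore estimated at 40000 nM, in a range from 12000 nM to 100000 nM.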

Compound 4, concentration lethal to 50% of the cells: 83200 nM
Beside the measured number, compound 4's estimate is 2.1-fold (0.32 log units) below it; low and high end bracket the measured number.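

In this assay, putting (4-fluorophenyl)sulfanyl in place of 3,4-dichlorophenoxy gives a 2.0-fold higher number from compound 1 to compound 4 (0.30 log units; within the scatter). This position, on an aromatic carbon next to the ring nitrogen and ortho to a phenyl group, therefore accepts two different aryl groups, one joined through sulfur and one through oxygen, and this read-out does not tell compound 1 and compound 4 apart. These are the only two true numbers shown, and steps to the other two compounds cannot be read: the limit of < 100000 nM in this assay, at which 2 of the 4 values shown sit.

As far as these compounds go, the sulfur link and the ring halogens changed together in this one step, so the weight of each alone remains open. Also open, from the compounds shown here alone, is how a nitrile on that aromatic ring, or a straight alkyl chain in place of the ring, would read in this assay.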